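Working notes on one aromatic group exchange

The source may report more compounds than this note shows. Statements on the series, on what has been measured and on what is new or still open speak of the compounds shown alone.

Measured so far:
Compound 1 `CCC(=O)c1cc(-c2ccc(S(N)(=O)=O)cc2)n(-c2ccc(C(F)(F)F)cn2)n1` gives 99400 nM
Compound 2 `NS(=O)(=O)c1ccc(-c2cc(C(=O)N3CCCC3)nn2-c2ccc(Cl)cc2)cc1` gives 57900 nM

In a physicochemical assay for solubility, read by HPLC, in phosphate buffer, measured as kinetic solubility, at pH 7.4 (on this read-out higher numbers stand for higher solubility and lower numbers for lower solubility), compound 2 gives 57900 nM and stands within the scatter of compound 1 (99400 nM), so the two values show no order.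

Compound 3 `NS(=O)(=O)c1ccc(-c2cc(C(=O)N3CCCC3)nn2-c2ccc(C(F)(F)F)cn2)cc1` is not yet measured. Compared with compound 2, it has 5-(trifluoromethyl)pyridin-2-yl in place of 4-chlorophenyl on an aromatic nitrogen and is otherwise unchanged.

For the measured compounds named here, no measured pair isolates this change. Compound 1 carries the same 5-(trifluoromethyl)pyridin-2-yl and gives 99400 nM in its own setting. On that basis, no step beyond the scatter is expected in this assay, and no direction is assigned. The a 1.1-fold higher number from compound 2 to compound 3 (0.05 log units; within the scatter) expected here stays within the scatter. The estimate for compound 3 is 65000 nM with 25000 nM to 130000 nM as the expected range.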

Compound 3, solubility: 8800 nM
Beside the measured number, compound 3's estimate is 7.4-fold (0.87 log units) above it, outside the stated range (below it).
By their numbers in this assay, from the lowest: compound 3; then compounds 2 and 1 (each within the scatter of the next).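

In this assay the exchange of 4-chlorophenyl for 5-(trifluoromethyl)pyridin-2-yl on an aromatic nitrogen is not neutral when the carbonyl carbon carries pyrrolidin-1-yl: the result is a 6.6-fold lower number from compound 2 to compound 3 (0.82 log units; beyond the scatter) and lies beyond the scatter. With 5-(trifluoromethyl)pyridin-2-yl held in place, pyrrolidin-1-yl in place of ethyl on a carbonyl carbon gives an 11-fold lower number from compound 1 to compound 3 (1.05 log units; beyond the scatter) in the same assay, so this aromatic group does not by itself set a high or a low number. Nothing measured here gives a reason for either step.

From the compounds shown here alone, whether the aromatic exchange gives a step of similar size with ethyl on the carbonyl carbon remains open. Also open, going by these compounds, is where a morpholin-4-yl on the carbonyl carbon or an unsubstituted pyridin-2-yl on the aromatic nitrogen would stand.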